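The source may hold more compounds than are shown below. What is called first, only, known or untested is meant among the compounds shown, and "the series" means these compounds.

Going by the values given here, in a functional assay on cells for agonist activity at Free fatty acid receptor 1 (Mus musculus), read by FLIPR and calcium flux, with a stated time of 100 s (on this read-out lower numbers stand for an effect already at smaller amounts and higher numbers for an effect only at larger amounts of compound), compound 3 `Cc1cccc(Oc2ccc(N3CCC[C@H]3CC(=O)O)cc2)c1` gives 2400 nM, the lowest of the three numbers so far. Compound 1 `Cc1ccccc1COc1ccc(N2CCC[C@H]2CC(=O)O)cc1` gives 3400 nM, and compound 2 `O=C(O)C[C@@H]1CCCN1c1ccc(Oc2ccccc2F)cc1` gives 6900 nM. The step of a 1.4-fold lower number from compound 1 to compound 3 (0.15 log units; within the scatter) stays within the scatter, while the step of a 2.9-fold lower number from compound 2 to compound 3 (0.46 log units; beyond the scatter) lies beyond it. Compound 4 `CN(C)c1cccc(Oc2ccc(N3CCC[C@H]3CC(=O)O)cc2)c1` differs from compound 3 in one place: dimethylamino in place of methyl on an aromatic carbon. Both earlier steps also changed the ring on the oxygen, and both were modest, so a change of similar or smaller size is expected here, most likely toward a higher number, as the expected step of a 1.5-fold higher number from compound 3 to compound 4 (0.16 log units; within the scatter) states. On this basis compound 4 is expected to give about 3500 nM, within a range from 1500 nM to 8000 nM.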

Compound 4, half-maximal effective concentration: > 33000 nM
Compound 4 ended at the assay's limit; the forecaster's own chance of this, stated with the estimate: 5%; middle value at least 9.4-fold (0.97 log units) away from the limit.
By their numbers in this assay, from the lowest: compounds 3 and 1 (each within the scatter of the next); then compound 2. At a limit, above all of these: compound 4.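

In this assay, going by these compounds alone, replacing methyl with dimethylamino on this aromatic carbon gives an at least 13-fold higher number from compound 3 to compound 4 (1.13 log units; beyond the scatter), a far larger change than any among the earlier compounds, which differed only in the group on the oxygen. The value of compound 4 is a limit of the assay, not a number. This position, meta to a large group, therefore does not accept every replacement for methyl.

The compounds shown leave open whether the added nitrogen or the larger group matters more. An ethyl group, with carbon only, or a plain amine at this place would help separate the two.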